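The source may hold more compounds than are shown below. What is called first, only, known or untested is meant among the compounds shown, and "the series" means these compounds.

Compound 1 `COc1ccc(S(=O)(=O)N2CCc3cccc(-c4ccco4)c32)cc1`: 42 nM
Compound 2 `COc1ccc(S(=O)(=O)N2CCc3cccc(-c4ccc(F)cc4)c32)cc1`: 79 nM
Compound 3 `COc1ccc(-c2cccc3c2N(S(=O)(=O)c2ccc(OC)cc2)CC3)cc1`: 211 nM

In a functional assay on MKN-45 cells (Homo sapiens) for inhibition, with a stated time of 72 h (a higher number here means a weaker inhibitor, a lower number a stronger inhibitor), compound 3 has the highest number of the three, at 211 nM. Compound 4 `COc1ccc(S(=O)(=O)N2CCc3cccc(-c4cccc(F)c4)c32)cc1` has 3-fluorophenyl in place of 4-methoxyphenyl on an aromatic carbon. The closest guide is a 2.7-fold higher number from compound 2 to compound 3 (0.43 log units; beyond the scatter), where compound 2 carries 4-fluorophenyl. Also relevant are a 5.0-fold higher number from compound 1 to compound 3 (0.70 log units; beyond the scatter) and a 1.9-fold higher number from compound 1 to compound 2 (0.27 log units; within the scatter), the last lying within the scatter. Among the measured compounds shown here, no measured compound carries 3-fluorophenyl, so the comparison is indirect. A modest step towards a lower number is therefore expected in this assay, with compound 4 landing near compound 2. The expected change is a 2.3-fold lower number from compound 3 to compound 4 (0.37 log units; beyond the scatter). Compound 4 is estimated at 90 nM, with an expected range of 35 nM to 220 nM.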

Compound 4, half-maximal inhibitory concentration: 84.7 nM
Compound 4: middle estimate off by 1.1-fold (0.03 log units), on the high side; low and high end bracket the measured number.
By their numbers in this assay, from the lowest: compounds 1, 2 and 4 (each within the scatter of the next); then compound 3.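

In this assay, moving the fluoro substituent, with 3-fluorophenyl in place of 4-fluorophenyl, leaves the number within the scatter (a 1.1-fold higher number from compound 2 to compound 4 (0.03 log units; within the scatter)), so the two fluorophenyl isomers are not separated. Replacing 4-methoxyphenyl brings a modest change beyond the scatter (a 2.5-fold lower number from compound 3 to compound 4 (0.40 log units; beyond the scatter)), while compound 4 remains within the scatter of the furan-2-yl compound (a 2.0-fold higher number from compound 1 to compound 4 (0.30 log units; within the scatter)), leaving only compound 3 apart from the other three. No available evidence explains this difference. On these data alone, whether an amine or a carboxylic acid on the phenyl ring at this position would fit with compounds 1, 2 and 4 or with compound 3 remains open.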